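A few compounds are considered here, and "the series" means these few. Any claim that something is new, unique, unknown or untested is made for them only; others in the source may bear on it.

Measured so far: compound 1 `O=C(/C(=C\c1c(O)cc(O)cc1O)S(=O)(=O)c1ccccc1Br)c1ccc(Cl)cc1`, 50000 nM; compound 2 `Cc1ccc(S(=O)(=O)/C(=C/c2ccc(Br)cc2)C(=O)c2ccc(Br)cc2)cc1`, 10000 nM; compound 3 `Cc1ccc(S(=O)(=O)/C(=C/c2c(O)cc(O)cc2O)C(=O)c2ccc(Cl)cc2)cc1`, > 100000 nM.

In a functional assay on DU-145 cells (Homo sapiens) for inhibition, read by trypan blue exclusion, with a stated time of 96 h (on this read-out lower numbers stand for stronger inhibition of growth and higher numbers for weaker inhibition of growth), compound 3 gives only a limit, > 100000 nM. Compound 2 gives the lowest of the two numbers in this assay, 10000 nM, and compound 1 gives 50000 nM. The change 2-bromophenyl in place of 4-methylphenyl on a sulfonyl sulfur gives the step of an at least 2.0-fold lower number from compound 3 to compound 1 (0.30 log units; that floor lies within the scatter), a floor only because compound 3 sits at the limit of > 100000 nM in this assay, at which 1 of the 3 values shown sits. Compound 4 `O=C(/C(=C\c1ccc(Br)cc1)S(=O)(=O)c1ccccc1Br)c1ccc(Br)cc1` carries the same change, (2-bromophenyl in place of 4-methylphenyl on a sulfonyl sulfur), on the core of compound 2; how that core differs from the core of compound 3 is not broken down here. Compound 4 is expected to show the step of a 2.0-fold lower number from compound 2 to compound 4 (0.30 log units; within the scatter) in this assay, resting on the step seen from compound 3 to compound 1 and on compound 2 at 10000 nM. Compound 4 is therefore estimated at 5000 nM, between 1500 nM and 30000 nM.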

Compound 4, concentration for 50% growth inhibition: 1000 nM
Estimate against measurement, compound 4: 5.0-fold (0.70 log units) above; the measured number lies below the stated range.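

In this assay, putting 2-bromophenyl in place of 4-methylphenyl on a sulfonyl sulfur gives a 10-fold lower number from compound 2 to compound 4 (1.00 log units; beyond the scatter), so on the core of compound 2 the change goes with stronger inhibition of growth. Set beside the earlier case, the two steps compare as follows: the same change on two cores in this assay, an at least 2.0-fold lower number (0.30 log units; that floor lies within the scatter) from compound 3 to compound 1 and a 10-fold lower number (1.00 log units; beyond the scatter) from compound 2 to compound 4; the limit leaves it open whether they differ. Compound 3 gives only a limit, so the result does not show that the size of the step carries from one core to the other: the limit of > 100000 nM in this assay, at which 1 of the 4 values shown sits.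

The compounds shown leave open whether the change would act in the same way on any further core. They also do not tell what an amine, a carboxylic acid or a longer chain would do in place of the 2-bromophenyl.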